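Dropping a Fluoro Group: Effect on Receptor Binding

The compounds below may be only part of what the source reports. "The series", "measured", "known", "first", "only" and "open" are said of these compounds alone.

Compound 1 `COc1ccc2ncc(S(=O)(=O)c3ccc(C)cc3)c(N3CCC(C)CC3)c2c1` and compound 2 `COc1ccc2ncc(S(=O)(=O)c3ccc(C)c(F)c3)c(N3CCC(C)CC3)c2c1` share one core. In an assay on isolated protein for displacement of a labelled ligand from metabotropic glutamate receptor 5 (Homo sapiens), with a stated time of 60 min, tested at 1 uM (a lower number here means less inhibition, a higher number more inhibition at the concentration tested (going by the name of the read-out)), compound 1 gives 90%, while compound 2 gives 73%. The change that separates them is hydrogen in place of fluoro on an aromatic carbon, and it made a step of a number 17 percentage points higher from compound 2 to compound 1 (beyond the scatter). Compound 3 `Cc1ccc(S(=O)(=O)c2cnc3cc(F)ccc3c2N2CCC(C)CC2)cc1F` rests on a different core; the difference between the cores of compound 3 and compound 2 is not broken down here. In this assay compound 3 gives 89%, a number within the scatter of compound 1 and beyond the scatter relative to compound 2. Compound 4 `Cc1ccc(S(=O)(=O)c2cnc3cc(F)ccc3c2N2CCC(C)CC2)cc1` has not yet been measured. It differs from compound 3 by hydrogen in place of fluoro on an aromatic carbon, the same change as from compound 2 to compound 1; among these compounds it occurs twice. Since compound 3 already gives 89%, the room above it is small, so the coming step is expected to be smaller than a number 17 percentage points higher from compound 2 to compound 1 (beyond the scatter). The step is expected to be a number 4 percentage points higher from compound 3 to compound 4 (within the scatter). Compound 4 is expected to give 93% in this assay, between 85% and 99%.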

Compound 4, a percentage reported as inhibition, at one concentration (the size of the read-out at that concentration, not a potency): 88%
For compound 4 the middle estimate is 5 percentage points above the measured one; the range from low to high includes it.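

On the core of compound 3, the change from 3-fluoro-4-methylphenyl to 4-methylphenyl made a step in this assay of a number 1 percentage points lower from compound 3 to compound 4 (within the scatter), so compound 3 and compound 4 cannot be told apart in this assay. The change therefore did not carry over in size from one core to the other: the same change on two cores in this assay, a number 17 percentage points higher (beyond the scatter) from compound 2 to compound 1 and a number 1 percentage points lower (within the scatter) from compound 3 to compound 4, 18 percentage points apart, beyond the scatter of two such steps Two pairs show only that the result of this change depends on the core it sits on here; they do not show what in the cores accounts for the gap, how the change would behave on a further core, or how potency would shift, since the read-out comes from a single concentration.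

The compounds shown leave open whether a chloro or a nitrile group in place of the fluoro would follow the result on either core. All four compounds also carry a methyl group on that ring, so the same change alongside an ethyl group remains an open question.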